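A Trifluoromethoxy Swap on a Growth Inhibitor

This account rests on a few compounds, and the source may have more. Where it says the series, first, only, none or still open, it means among the compounds named here.

compound 1 `Cc1ccc2[nH]c(-c3ccc(-c4ccc(-c5ccc(N(C)C)cc5)cc4)cc3)nc2c1` gives 4230 nM
compound 2 `COc1cc(-c2ccc(-c3ccc(-c4nc5ccccc5[nH]4)cc3)cc2)cc(OC)c1OC` gives 9430 nM
compound 3 `CN(C)c1ccc(-c2ccc(-c3ccc(-c4nc5c(O)cccc5[nH]4)cc3)cc2)cc1` gives 8250 nM

These values come from a functional assay on HOP-62 cells (Homo sapiens) for inhibition, read by sulforhodamine B assay (a higher number here means a weaker inhibitor of growth, a lower number a stronger inhibitor of growth), and the number for compound 1 lies within the scatter of compound 3 but is lower than that of compound 2 by more than the scatter. Going by the values given here, compound 4 `Cc1ccc2[nH]c(-c3ccc(-c4ccc(-c5ccc(OC(F)(F)F)cc5)cc4)cc3)nc2c1` keeps the core of compound 1 and has trifluoromethoxy in place of dimethylamino on an aromatic carbon as its one change. Among the compounds with values here, the only measured step of a 2.0-fold higher number from compound 1 to compound 3 (0.29 log units; within the scatter) concerns a different group, so it bears on this swap only indirectly. Within the data shown here, no measured pair isolates this change, so no step beyond the scatter is expected. The estimated step is a 1.2-fold higher number from compound 1 to compound 4 (0.07 log units; within the scatter) and remains uncertain. For compound 4 the expected value is 5000 nM with an estimated range from 2000 nM to 12000 nM at this stage.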

Compound 4, concentration for 50% growth inhibition: 24200 nM
For compound 4 the middle estimate is 4.8-fold (0.68 log units) below the measured one; measured number above the stated range.
By their numbers in this assay, from the lowest: compounds 1, 3 and 2 (each within the scatter of the next, the first and the last beyond it); then compound 4.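

Putting trifluoromethoxy in place of dimethylamino gives (a 5.7-fold higher number from compound 1 to compound 4 (0.76 log units; beyond the scatter)), so compound 4 is a weaker inhibitor of growth than compound 1. Going by these compounds alone, the one earlier step stayed within the scatter, so this is the first sign that a change can clearly shift the number, and here the change sits on an aromatic carbon para to a large group. Nothing measured here explains this loss.

From the compounds shown here alone, whether an unsubstituted amine or a chlorine atom at this place would match compound 1 remains open. So does whether the same swap would have a similar effect on the core of compound 3.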